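Hydroxymethyl to methyl on the shared core

This account rests on a few compounds, and the source may have more. Where it says the series, first, only, none or still open, it means among the compounds named here.

Values in a functional assay on MCF7 cells (Homo sapiens) for cytotoxicity, read by MTT assay, with a stated time of 24 h; a higher number here means a weaker inhibitor, a lower number a stronger inhibitor
- compound 1 `O=C(NCCCCN1CCC(Cc2ccccc2)CC1)c1ccc(CO[N+](=O)[O-])cc1` gives 26000 nM as a number
- compound 2 `O=C(NCCCCN1CCC(Cc2ccccc2)CC1)c1ccc(CO)cc1` gives > 100000 nM as a limit
- compound 3 `Cc1ccc(C(=O)NCCCCN2CCC(Cc3ccccc3)CC2)cc1` is not yet measured

Compound 2 stands at the limit of this assay (> 100000 nM), and no number is known for it. The change to compound 3 is hydrogen in place of hydroxy on a saturated chain carbon bound to an aromatic carbon (hydroxymethyl to methyl). Going by the values given here, the only measured step at this group is the loss of the nitro on the oxygen of compound 1 (an at least 3.8-fold higher number from compound 1 to compound 2 (0.58 log units; beyond the scatter)), and that step ends in a limit. Compound 3 carries no nitro either, so it is expected to stay close to compound 2 in this assay. The expected move is small (an at least 1.4-fold lower number from compound 2 to compound 3 (0.15 log units; that floor lies within the scatter)), toward a lower number if one shows. The estimated value for compound 3 is 70000 nM (range 25000 nM to 150000 nM).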

Compound 3, half-maximal inhibitory concentration: 87000 nM
The estimate for compound 3 lay 1.2-fold (0.09 log units) below the measured number; low and high end bracket the measured number.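

In this assay, the methyl group of compound 3 yields a measured number, so a finite reading at this position does not require nitrooxy. The change from hydroxymethyl to methyl gives an at least 1.1-fold lower number from compound 2 to compound 3 (0.06 log units; that floor lies within the scatter), but its true size cannot be read because compound 2 stands at a limit: the limit of > 100000 nM in this assay, at which 1 of the 3 values shown sits. Hydrogen in place of nitrooxy gives a 3.3-fold higher number from compound 1 to compound 3 (0.52 log units; beyond the scatter), so removing the whole group produces a step beyond the scatter, a firmer reading than the step that ends in the limit.

Whether hydroxymethyl and methyl truly differ in this assay remains unresolved. The compounds shown also leave open how an amine or a carboxylic acid at this saturated chain carbon would compare, and whether nitrooxy on a longer chain would give a lower number than compound 1.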